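Long half-lives and the step to compound 3

The compounds below may be only part of what the source reports. "The series", "measured", "known", "first", "only" and "open" are said of these compounds alone.

Measured in an unclassified assay for pharmacokinetics, read by NMR, tested at 2 mg/mL; a higher number here means that the compound lasts longer, a lower number that the compound disappears faster:
- compound 1 `COc1ccc(/N=N\c2ccc(F)c(C(=O)Nc3cnc4[nH]nc(OC)c4c3)c2F)cc1`: > 10 h (a limit)
- compound 2 `COc1n[nH]c2ncc(NC(=O)c3c(F)ccc(/N=N\c4ccc(F)cc4)c3F)cc12`: > 20 h (a limit)

Compound 2 has no exact value in this assay, only the limit > 20 h. Compound 1 is likewise known only by a limit, > 10 h.

Compound 3 `COc1n[nH]c2ncc(NC(=O)c3c(F)ccc(/N=N\c4ccccc4C)c3F)cc12` carries 2-methylphenyl in place of 4-fluorophenyl on a double-bonded nitrogen.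

Within the data shown here, the one measured step is a step that the two limits leave unreadable from compound 1 to compound 2, with fluoro in place of methoxy on an aromatic carbon. It is a different change and gives no size to carry over, so no direction can be argued and no step beyond the scatter is expected. The starting point is the limit held by compound 2, > 20 h. The expected step is a step that the limit leaves unreadable from compound 2 to compound 3. For compound 3 the estimated half-life is 25 h, with an expected range from 10 h to 60 h.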

Compound 3, half-life: > 70 h
Compound 3: a limit, no number (the forecaster's own chance of this, stated with the estimate: 60%); at least 2.8-fold (0.44 log units) between middle value and limit.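

Among these compounds, compound 1, compound 2 and compound 3 are each known in this assay only by a limit, so no step among them can be read. The compounds shown leave open the actual half-life of each and whether either change alters it.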